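Dinitrobenzoate esters: phenyl replacing hydrogen on the phenol ring

A few compounds are considered here, and "the series" means these few. Any claim that something is new, unique, unknown or untested is made for them only; others in the source may bear on it.

Compound 2 `O=C(Oc1ccccc1)c1cc([N+](=O)[O-])cc([N+](=O)[O-])c1` gives 1600 nM in an assay on isolated protein for inhibition of Polyunsaturated fatty acid 5-lipoxygenase (Homo sapiens), read by fluorescence, with a stated time of 10 min; on this read-out higher numbers stand for weaker inhibition and lower numbers for stronger inhibition. Among the three compounds measured so far it stands second highest: compound 3 `O=C(Oc1cccc(-c2ccccc2)c1)c1cc([N+](=O)[O-])cc([N+](=O)[O-])c1` gives 8700 nM, and compound 1 `Cc1cccc(OC(=O)c2cc([N+](=O)[O-])cc([N+](=O)[O-])c2)c1` gives 6 nM. The step of a 5.4-fold higher number from compound 2 to compound 3 (0.74 log units; beyond the scatter) is modest, whereas the steps of a 270-fold higher number from compound 1 to compound 2 (2.43 log units; beyond the scatter) and a 1500-fold higher number from compound 1 to compound 3 (3.16 log units; beyond the scatter) are both large, so the numbers in this small set span a wide range.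

Compound 4 `O=C(Oc1ccc(-c2ccccc2)cc1)c1cc([N+](=O)[O-])cc([N+](=O)[O-])c1` has not yet been measured. It differs from compound 2 by phenyl in place of hydrogen on an aromatic carbon. Going by the values given here, the one measured step of the same kind, a phenyl entering in place of a hydrogen on that ring, is a 5.4-fold higher number from compound 2 to compound 3 (0.74 log units; beyond the scatter), and nothing else bears directly on this change. A step of comparable, modest size towards a higher number is therefore expected in this assay, with the uncertainty that the phenyl now enters at a different position on the ring.

For compound 4 the expected value is 6000 nM, with a range from 1500 nM to 25000 nM, which would mean an expected step of a 3.8-fold higher number from compound 2 to compound 4 (0.57 log units; beyond the scatter).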

Compound 4, half-maximal inhibitory concentration: > 50000 nM
Compound 4: no number, only a limit (the forecaster's own chance of this, stated with the estimate: 10%); middle value at least 8.3-fold (0.92 log units) from the limit.
By their numbers in this assay, from the lowest: compound 1; then compound 2; then compound 3. At a limit, above all of these: compound 4.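

Compound 4 gives only a limit in this assay, not a number: the limit of > 50000 nM in this assay, at which 1 of the 4 values shown sits.

Phenyl in place of hydrogen para to a large group is a large change, an at least 31-fold higher number from compound 2 to compound 4 (1.49 log units; beyond the scatter), while the other placement of phenyl on this ring gives a modest one, a 5.4-fold higher number from compound 2 to compound 3 (0.74 log units; beyond the scatter). Both placements therefore move towards higher numbers, but the position of the phenyl governs the size of the step, and for this position the size is bounded on one side only.

On these data alone, it remains open how far past the limit compound 4 lies, and whether the loss here needs a group as large as phenyl. Methyl, which in compound 1 gives 6 nM at its own position, and smaller groups such as methoxy or an amine are untested in the data shown para to a large group.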